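Series notes: aryl-to-pentyl swap at the shared core

A few compounds are considered here, and "the series" means these few. Any claim that something is new, unique, unknown or untested is made for them only; others in the source may bear on it.

Compound 1 `COc1cccc(-c2nc3c(-c4cccc(Cl)c4)n[nH]c3c(=O)n2NC(=O)c2ccccc2)c1` gives 91% in a functional assay on HT-29 cells (Homo sapiens) for cytotoxicity, read by sulforhodamine B assay, with a stated time of 2 days, tested at 100 uM (a higher number here means more inhibition at the concentration tested (going by the name of the read-out), a lower number less inhibition), and compound 2 `COc1cccc(-c2nc3c(-c4ccc(Cl)cc4)n[nH]c3c(=O)n2NC(=O)c2ccccc2)c1` gives 87.3%. The step of a number 3.7 percentage points lower from compound 1 to compound 2 (within the scatter) is within the scatter, so compound 2 holds the lower of the two numbers without being separable from compound 1. Compound 3 `CCCCCc1nc2c(-c3ccc(Cl)cc3)n[nH]c2c(=O)n1NC(=O)c1ccccc1` differs from compound 2 by pentyl in place of 3-methoxyphenyl on an aromatic carbon. Among the measured compounds shown here, no measured step concerns this position; both measured compounds keep the 3-methoxyphenyl, so no direction can be read from them. Compound 3 is expected at 75%, between 45% and 95%. The step expected is a number 12.3 percentage points lower from compound 2 to compound 3 (beyond the scatter).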

Compound 3, a percentage reported as inhibition, at one concentration (the size of the read-out at that concentration, not a potency): 90.1%
Beside the measured number, compound 3's estimate is 15.1 percentage points below it; measured number inside the range.
By their numbers in this assay, from the lowest: compounds 2, 3 and 1 (each within the scatter of the next).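

Pentyl in place of 3-methoxyphenyl gives a number 2.8 percentage points higher from compound 2 to compound 3 (within the scatter) in this assay, the only measured change at this position. With the 4-chlorophenyl group held constant, the read-out at this one concentration therefore does not depend on an aromatic ring at this position. No evidence is available that explains this result.

On these data alone, whether a shorter chain such as ethyl, a carboxylic acid or an amine at this position would give a similar number remains open. A single-concentration read-out also leaves any difference in potency between compound 2 and compound 3 unresolved.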